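The source may report more compounds than this note shows. Statements on the series, on what has been measured and on what is new or still open speak of the compounds shown alone.

Compound 1 `CN(CCC#N)C[C@H]1CN(c2ccc(-n3cc(-c4ccccn4)cn3)c(F)c2)C(=O)O1` gives 1.9 in a physicochemical assay for lipophilicity, read by HPLC, measured as octanol-water partition (on this read-out higher numbers stand for higher lipophilicity and lower numbers for lower lipophilicity), the second highest of the three numbers measured; compound 3 `CCNC(=O)NC[C@H]1CN(c2ccc(-n3cc(-c4ccccn4)cn3)c(F)c2)C(=O)O1` gives 2.45, and compound 2 `O=C1CNC(=O)N1C[C@H]1CN(c2ccc(-n3cc(-c4ccccn4)cn3)c(F)c2)C(=O)O1` gives 1.25. Compound 4 `O=C(NC[C@H]1CN(c2ccc(-n3cc(-c4ccccn4)cn3)c(F)c2)C(=O)O1)C(F)F` differs from compound 1 in this way: ((difluoromethyl)carbonyl)amino in place of (2-cyanoethyl)(methyl)amino on a saturated chain carbon bound to a saturated ring carbon. The step that bears most on it is a number 0.55 log units higher from compound 1 to compound 3 (beyond the scatter), where a group with one hydrogen-bond donor and one acceptor likewise replaced the (2-cyanoethyl)(methyl)amino group; the opposite move, a number 0.65 log units lower from compound 1 to compound 2 (beyond the scatter), went to a group with no donor. Since the entering group resembles the (ethylcarbamoyl)amino group in what is counted, a modest rise is expected, a number 0.40 log units higher from compound 1 to compound 4 (beyond the scatter). Compound 4 is therefore estimated at 2.3, with a range from 1.8 to 2.8.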

Compound 4, partition coefficient: 1.9
Estimate against measurement, compound 4: 0.40 log units above, and the stated range covers the measured number.
By their numbers in this assay, from the lowest: compound 2; then compounds 1 and 4 (each within the scatter of the next); then compound 3.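

In this assay, the ((difluoromethyl)carbonyl)amino group at this place gives no change at the digits printed from compound 1 to compound 4 (within the scatter), so a group that counts like the (ethylcarbamoyl)amino group need not read like it. On the carbonyl carbon alone, difluoromethyl in place of ethylamino gives a number 0.55 log units lower from compound 3 to compound 4 (beyond the scatter), which shows that this end of the group carries a measurable part of the difference, while the 2,5-dioxoimidazolidin-1-yl group stays apart, with a number 0.65 log units higher from compound 2 to compound 4 (beyond the scatter). No measurement here accounts for these steps.

The compounds shown leave open how methyl, trifluoromethyl or a longer alkyl chain on that carbonyl carbon would read, and whether a free amine at this place would follow the same order.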